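Pyrazole chalcone series: third methoxy on the ketone aryl

The source may report more compounds than this note shows. Statements on the series, on what has been measured and on what is new or still open speak of the compounds shown alone.

Working notes on the series. Compound 1 `COc1cc(-c2cc(/C=C/C(=O)c3ccc(Cl)c(Cl)c3)[nH]n2)cc(OC)c1OC` gives 4190 nM in a functional assay on SK-OV-3 cells (Homo sapiens) for inhibition, read by sulforhodamine B assay, with a stated time of 48 h; a higher number here means a weaker inhibitor of growth, a lower number a stronger inhibitor of growth. For the measured compounds named here, compound 2 `COc1ccc(C(=O)/C=C/c2cc(-c3cc(OC)c(OC)c(OC)c3)n[nH]2)cc1OC` gives 2790 nM in this assay; the one measured step is a 1.5-fold lower number from compound 1 to compound 2 (0.18 log units; within the scatter), 3,4-dimethoxyphenyl in place of 3,4-dichlorophenyl on a carbonyl carbon. Going by the values given here, compound 2 stands at the low end of the two numbers in hand, its only neighbour being compound 1, within the scatter.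

Compound 3 `COc1cc(C(=O)/C=C/c2cc(-c3cc(OC)c(OC)c(OC)c3)n[nH]2)cc(OC)c1OC` differs from compound 2 by methoxy in place of hydrogen on an aromatic carbon. Among the compounds with values here, no measured step adds a single methoxy to that ring; the only step available, a 1.5-fold lower number from compound 1 to compound 2 (0.18 log units; within the scatter), swaps the whole aryl group and lies within the scatter. Nothing in hand points to a move beyond the scatter, so compound 3 is expected to give 2600 nM (range 1000 nM to 7000 nM), an expected step of a 1.1-fold lower number from compound 2 to compound 3 (0.03 log units; within the scatter).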

Compound 3, concentration for 50% growth inhibition: 3200 nM
Compound 3: the middle estimate sits 1.2-fold (0.09 log units) below what was measured; measured number inside the range.
By their numbers in this assay, from the lowest: compounds 2, 3 and 1 (each within the scatter of the next).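

Methoxy in place of hydrogen on an aromatic carbon, ortho to a methoxy group and meta to a large group, is the first single-group change read on the ketone aryl. In this assay it gives (a 1.1-fold higher number from compound 2 to compound 3 (0.06 log units; within the scatter)), so the numbers for the dimethoxy and trimethoxy aryl groups cannot be told apart, and this place accepts the added methoxy without a step beyond the scatter. No measured data bear on why this step is so small.

Still open, as far as these compounds go, is whether a different group at this place, such as an amine or a carboxylic acid, would give a step beyond the scatter. Also open, from the compounds shown here alone, is whether a longer chain, such as ethoxy in place of the added methoxy, would do so.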